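The source may report more compounds than this note shows. Statements on the series, on what has been measured and on what is new or still open speak of the compounds shown alone.

Compound 1 `O=C1O[C@H]([C@@H](O)Cn2cc(-c3ccc(Br)cc3)nn2)C(OCc2ccccc2)=C1OCc1ccccc1`: 9420 nM
Compound 2 `CC(C)(C)OC(=O)N1CCN(C(=S)SCc2cn(C[C@H](O)[C@H]3OC(=O)C(OCc4ccccc4)=C3OCc3ccccc3)nn2)CC1`: > 100000 nM (a limit, not a number)

Among the measured compounds shown here, in a functional assay on HCT-116 cells (Homo sapiens) for antiproliferative activity, read by MTT assay, with a stated time of 72 h (a lower number here means a stronger inhibitor, a higher number a weaker inhibitor), compound 1 gives 9420 nM, the only actual number so far. Compound 2 is reported at > 100000 nM, which is a limit of the assay.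

Compound 3 `O=C1O[C@H]([C@@H](O)Cn2cc(CNS(=O)(=O)c3ccc(F)cc3)nn2)C(OCc2ccccc2)=C1OCc1ccccc1` keeps the core of compound 1 and changes one group: (((4-fluorophenyl)sulfonyl)amino)methyl in place of 4-bromophenyl on an aromatic carbon. For the measured compounds named here, no measured pair tests this replacement, so the expectation is weakly founded. With compound 1 at 9420 nM as the sole anchor, a moderate change in this assay is expected, and a wide range is needed. The expected step of a 1.9-fold higher number from compound 1 to compound 3 (0.28 log units; within the scatter) points toward weaker inhibition, beyond the usual scatter. For compound 3 the estimated value is 18000 nM, with an expected range of 5000 nM to 70000 nM.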

Compound 3, half-maximal inhibitory concentration: 22900 nM
Estimate against measurement, compound 3: 1.3-fold (0.10 log units) below; low and high end bracket the measured number.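

In this assay, replacing 4-bromophenyl with (((4-fluorophenyl)sulfonyl)amino)methyl on the aromatic carbon gives a 2.4-fold higher number from compound 1 to compound 3 (0.39 log units; beyond the scatter). This first step in the series shows that the position responds to its substituent, but only modestly: the aromatic ring no longer sits directly on the five-membered ring, and the entering group brings a hydrogen-bond donor and acceptors, yet compound 3 still gives a number. Compound 2, which differs in more than one place, is held only as a limit, not a number: the limit of > 100000 nM in this assay, at which 1 of the 3 values shown sits.

This single pair changes the linker and the halogen together, so their separate contributions cannot be told apart. From the compounds shown here alone, how a 4-fluorophenyl group, a simple amine or a carboxylic acid on this carbon would behave remains open.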